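Nitro in place of hydrogen on the aromatic carbon

This account rests on a few compounds, and the source may have more. Where it says the series, first, only, none or still open, it means among the compounds named here.

Compound 1 `O=C(CSC(=S)N[C@H]1CCOC1=O)Nc1ccccc1` gives > 128000 nM in a functional assay on SMMC-7721 cells (Homo sapiens) for cytotoxicity, read by MTT assay, with a stated time of 72 h (on this read-out lower numbers stand for stronger inhibition and higher numbers for weaker inhibition), which is a limit of the assay and not a number. Compound 2 `Cc1ccc(NC(=O)CSC(=S)N[C@H]2CCOC2=O)cc1` gives 32700 nM in this assay. Compound 3 `COc1ccc(NC(=O)CSC(=S)N[C@H]2CCOC2=O)cc1` also sits at a limit, giving > 128000 nM in this assay. Compound 4 `O=C(CSC(=S)N[C@H]1CCOC1=O)Nc1cccc([N+](=O)[O-])c1` differs from compound 1 by nitro in place of hydrogen on an aromatic carbon. For the measured compounds named here, no measured step introduces a nitro; the steps that start from compound 1 are an at least 3.9-fold lower number from compound 1 to compound 2 (0.59 log units; beyond the scatter) and a step that the two limits leave unreadable from compound 1 to compound 3, and an at least 3.9-fold higher number from compound 2 to compound 3 (0.59 log units; beyond the scatter) separates the two substituted compounds. With two of three values at the limit of > 128000 nM in this assay, at which 2 of the 3 values shown sit, a step beyond the scatter cannot be read with confidence, and a value at or near the limit is the default expectation. Compound 4 is expected around 100000 nM (range 25000 nM to 400000 nM) in this assay. The step of an at least 1.2-fold lower number from compound 1 to compound 4 (0.10 log units; that floor lies within the scatter) is an estimate only.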

Compound 4, half-maximal inhibitory concentration: > 128000 nM
Compound 4: no number, only a limit; the forecaster's own chance of this, stated with the estimate: 60%; at least 1.2-fold (0.10 log units) between middle value and limit.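

Compound 4 gives > 128000 nM in this assay, which is a limit and not a number. For the compounds shown here, compound 1 also sits at a limit, and no step between compound 1 and compound 4 can be read. The compounds shown leave open whether nitro in place of hydrogen on an aromatic carbon changes the read-out at all.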